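The source may hold more compounds than are shown below. What is called first, only, known or untested is meant among the compounds shown, and "the series" means these compounds.

Compound 1 `COc1ccc(-c2cc3ccccc3nc2/C=C/C(=O)c2cccs2)cc1` gives 5440 nM in a functional assay on NCI-H460 cells (Homo sapiens) for antiproliferative activity, read by XTT assay, with a stated time of 72 h; a higher number here means a weaker inhibitor, a lower number a stronger inhibitor. Compound 2 `COc1ccc(-c2cc3ccccc3nc2/C=C/C(=O)c2ccccn2)cc1` gives 6260 nM in this assay. Compound 3 `COc1ccc(-c2cc3ccccc3nc2/C=C/C(=O)c2ccc[nH]2)cc1` gives only a limit, > 10000 nM, in this assay.

From the compounds shown here alone, compound 3 thus stands at the assay ceiling, as recorded by the limit of > 10000 nM in this assay, at which 1 of the 3 values shown sits, so its true value is unknown. Both swaps at the carbonyl carbon leading to it, an at least 1.8-fold higher number from compound 1 to compound 3 (0.26 log units; that floor lies within the scatter) and an at least 1.5-fold higher number from compound 2 to compound 3 (0.20 log units; that floor lies within the scatter), sat within the scatter, as did a 1.2-fold higher number from compound 1 to compound 2 (0.06 log units; within the scatter). Compound 4 `COc1ccc(-c2cc3ccccc3nc2/C=C/C(=O)c2cnc(N)nc2C)cc1` differs from compound 3 by 2-amino-4-methylpyrimidin-5-yl in place of 1H-pyrrol-2-yl on a carbonyl carbon. Since no exchange of the ring on the carbonyl carbon has moved this assay beyond the scatter, the step that the limit leaves unreadable from compound 3 to compound 4 is expected to stay within it, with compound 4 quite possibly again reported only as a limit. Compound 4 is estimated at 12000 nM, between 4000 nM and 40000 nM.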

Compound 4, half-maximal inhibitory concentration: > 10000 nM
Compound 4 was reported as a limit; the forecaster's own chance of this, stated with the estimate: 55%; the middle value lies beyond the limit too.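

Compound 4, with 2-amino-4-methylpyrimidin-5-yl on the carbonyl carbon, gives only a limit in this assay, the same limit as compound 3: the limit of > 10000 nM in this assay, at which 2 of the 4 values shown sit. The steps read an at least 1.5-fold higher number from compound 2 to compound 4 (0.20 log units; that floor lies within the scatter) and an at least 1.8-fold higher number from compound 1 to compound 4 (0.26 log units; that floor lies within the scatter), while the step between the two limited compounds cannot be read. Readable values at this position therefore remain confined to compound 1 and compound 2.

From the compounds shown here alone, the true values of compound 3 and compound 4 stay open. So does whether a phenyl ring or a morpholine ring on this carbonyl carbon would move the assay beyond the scatter.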